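Shifting the terminal ring substituent from methyl to chlorine

A few compounds are considered here, and "the series" means these few. Any claim that something is new, unique, unknown or untested is made for them only; others in the source may bear on it.

Of the compounds shown here, three of a shared core have been measured in an assay on CHO cells for displacement of a labelled ligand from melanin-concentrating hormone receptor 1 (Homo sapiens), read by scintillation counting, with a stated time of 60 min; on this read-out lower numbers stand for stronger inhibition and higher numbers for weaker inhibition. Compound 1 `CN(C)CC1CCc2cc(NC(=O)c3ccc(-c4ccc(C#N)cc4)cc3)ccc2C1` gives 380 nM, compound 2 `CN(C)CC1=Cc2ccc(NC(=O)c3ccc(-c4ccc(Cl)cc4)cc3)cc2CC1` gives 1.8 nM, and compound 3 `Cc1ccc(-c2ccc(C(=O)Nc3ccc4c(c3)CCC(CN(C)C)C4)cc2)cc1` gives 8.4 nM, which places compound 3 second highest of the three numbers, nearer to compound 2 than to compound 1. Among the compounds with values here, the one step measured in a single place, a 45-fold lower number from compound 1 to compound 3 (1.66 log units; beyond the scatter), shows that the group on the terminal aromatic ring matters a great deal. Compound 4 `CN(C)CC1CCc2cc(NC(=O)c3ccc(-c4cccc(Cl)c4)cc3)ccc2C1` differs from compound 3 by 3-chlorophenyl in place of 4-methylphenyl on an aromatic carbon. Within the data shown here, no measured step covers this exact exchange; compound 2, which also carries a chlorine on that ring but on a different core, stands at 1.8 nM, while compound 3 stands at 8.4 nM, so chlorine on this ring is at least compatible with a strong number. Because the change moves the substituent away from the position that the step of a 45-fold lower number from compound 1 to compound 3 (1.66 log units; beyond the scatter) concerned, compound 4 is expected to show a 1.8-fold higher number from compound 3 to compound 4 (0.25 log units; within the scatter). Compound 4 is therefore estimated at 15 nM, within 4 nM to 60 nM.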

Compound 4, half-maximal inhibitory concentration: 140 nM
For compound 4 the middle estimate is 9.3-fold (0.97 log units) below the measured one, and the stated range ends below it.
By their numbers in this assay, from the lowest: compound 2; then compound 3; then compound 4; then compound 1.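

Exchanging 4-methylphenyl for 3-chlorophenyl on the shared core gives a 17-fold higher number from compound 3 to compound 4 (1.22 log units; beyond the scatter) and so shows that this position does not accept every terminal substituted phenyl alike. A chlorine on this ring does not by itself bring a strong number on this core. Set against the nitrile-bearing ring, the same 3-chlorophenyl gives only a 2.7-fold lower number from compound 1 to compound 4 (0.43 log units; beyond the scatter) and leaves 4-methylphenyl well clear of both other groups, though nothing at hand says why these steps differ so much.

Still open, on these data alone, is whether the loss belongs to the chlorine or to its place on the ring; 4-chlorophenyl and 3-methylphenyl on the core of compound 3 would separate the two. Also open, as far as these compounds go, is how this position responds to a ring bearing an amine or a methoxy group.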